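Shortening the chain on the four-membered ring of compound 3

This account rests on a few compounds, and the source may have more. Where it says the series, first, only, none or still open, it means among the compounds named here.

Compound 3 `c1ccc2c(c1)CC2CCCCN1CCN(c2cccc3c2OCCO3)CC1` gives the highest number of the three compounds measured in a functional assay on the whole organism for antagonist activity, with Rattus norvegicus as the target (on this read-out lower numbers stand for an effect already at smaller amounts and higher numbers for an effect only at larger amounts of compound), at 5 mg/kg. Compound 2 `Clc1cccc2c1CC2CCN1CCN(c2cccc3c2OCCO3)CC1` gives 1.25 mg/kg, and compound 1 `c1ccc2c(c1)CCC2CCCN1CCN(c2cccc3c2OCCO3)CC1` gives 0.16 mg/kg. Within the data shown here, the one step that is fully described connects compound 1 and compound 3: a 31-fold higher number from compound 1 to compound 3 (1.49 log units; beyond the scatter).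

Compound 4 `c1ccc2c(c1)CC2CCCN1CCN(c2cccc3c2OCCO3)CC1` differs from compound 3 by a group of 8 heavy atoms (8 carbon; one four-membered non-aromatic ring of carbon only, one six-membered aromatic ring of carbon only) in place of a group of 9 heavy atoms (9 carbon; one four-membered non-aromatic ring of carbon only, one six-membered aromatic ring of carbon only), on a saturated chain carbon, three bonds along the chain from an amine nitrogen in a ring. Among the measured compounds shown here, no measured pair shows this exact change, so the step from compound 1 to compound 3 is the only guide, and it concerns the whole group rather than its length alone. Compound 1 and compound 2 both carry a group of fewer atoms on this chain carbon than compound 3 and both give lower numbers, so the expected direction for compound 4 is toward a lower number, though of uncertain size. Compound 4 is therefore estimated at 1.25 mg/kg, within 0.3 mg/kg to 5 mg/kg, which amounts to an expected step of a 4.0-fold lower number from compound 3 to compound 4 (0.60 log units; beyond the scatter).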

Compound 4, minimum effective dose: 0.16 mg/kg
Beside the measured number, compound 4's estimate is 7.8-fold (0.89 log units) above it; the measured number lies below the stated range.
By their numbers in this assay, from the lowest: compounds 1 and 4 (each within the scatter of the next); then compound 2; then compound 3.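

With the four-membered ring kept, the group of 8 heavy atoms in place of the group of 9 heavy atoms, on a saturated chain carbon, three bonds along the chain from an amine nitrogen in a ring, gives a large step in this assay (a 31-fold lower number from compound 3 to compound 4 (1.49 log units; beyond the scatter)), so the size of this group alone can move the read-out strongly. The four-membered and five-membered ring groups are not told apart at this place (no change at the digits printed from compound 1 to compound 4 (within the scatter)), which lets the earlier step between compound 1 and compound 3 be matched without any change of ring size. The group without chlorine, at its own place two bonds along the chain, also gives a modest step (a 7.8-fold lower number from compound 2 to compound 4 (0.89 log units; beyond the scatter)).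

From the compounds shown here alone, what a chlorine on the group of compound 4 or a longer chain on the five-membered ring would give stays open. Nothing available explains why these steps take the sizes they do.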